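A Methyl Group on the Core and What It Costs

The source may hold more compounds than are shown below. What is called first, only, known or untested is meant among the compounds shown, and "the series" means these compounds.

Three compounds have been measured in a functional assay on V79-379A cells (Cricetulus griseus) for cytotoxicity, read by MTT assay, in the presence of a further agent that is not named here; a higher number here means a weaker inhibitor, a lower number a stronger inhibitor:

Compound 1, `COC1=CC(=O)c2c(c(COC(=O)c3ccc(F)cc3)cn2C)C1=O`, gives 50 nM.
Compound 2, `COC1=CC(=O)c2c(c(COC(=O)c3ccc(F)cc3)c(C)n2C)C1=O`, gives 300 nM.
Compound 3, `COC1=CC(=O)c2c(c(COC(N)=O)cn2C)C1=O`, gives 40 nM.

Compounds 1 and 2 share a core and differ in one place: methyl in place of hydrogen on an aromatic carbon. This change produced a 6.0-fold higher number from compound 1 to compound 2 (0.78 log units; beyond the scatter), so the added methyl weakened the compound.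

Compound 3 carries a different side chain on the same core. How the two cores of the present pair differ is told by amino in place of 4-fluorophenyl on a carbonyl carbon. That exchange made a 1.3-fold lower number from compound 1 to compound 3 (0.10 log units; within the scatter), so compound 1 and compound 3 show no difference that can be trusted.

Compound 4, `COC1=CC(=O)c2c(c(COC(N)=O)c(C)n2C)C1=O`, is not yet measured. It differs from compound 3 by methyl in place of hydrogen on an aromatic carbon. Among the compounds with values here, this is the same kind of change as the one from compound 1 to compound 2: the methyl sits next to the ring nitrogen in both, but in compound 4 it is next to the ring atom that bears a (carbamoyloxy)methyl group, whereas in compound 2 it is next to the ring atom that bears a large group.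

Because a 6.0-fold higher number from compound 1 to compound 2 (0.78 log units; beyond the scatter) weakened the earlier pair, a comparable loss is expected here, and the step from compound 3 to compound 4 is estimated at a 6.0-fold higher number from compound 3 to compound 4 (0.78 log units; beyond the scatter). Compound 4 is therefore expected to give about 240 nM, with a likely range from 100 nM to 600 nM.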

Compound 4, half-maximal inhibitory concentration: 300 nM
Beside the measured number, compound 4's estimate is 1.3-fold (0.10 log units) below it; the range from low to high includes it.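

In this assay, methyl in place of hydrogen on the aromatic carbon gave a 7.5-fold higher number from compound 3 to compound 4 (0.88 log units; beyond the scatter), and the loss seen on the first pair carried over to the second: the same change on two cores in this assay, a 6.0-fold higher number (0.78 log units; beyond the scatter) from compound 1 to compound 2 and a 7.5-fold higher number (0.88 log units; beyond the scatter) from compound 3 to compound 4, 1.3-fold (0.10 log units) apart, within the scatter of two such steps. The exchange of amino for 4-fluorophenyl on a carbonyl carbon gave no change at the digits printed from compound 2 to compound 4 (within the scatter), so this swap made no difference that can be trusted, whether or not the methyl was present: the same change on two cores in this assay, a 1.3-fold lower number (0.10 log units; within the scatter) from compound 1 to compound 3 and no change at the digits printed (within the scatter) from compound 2 to compound 4, 1.3-fold (0.10 log units) apart, within the scatter of two such steps. These two matched pairs show that the methyl's cost and the harmlessness of the side-chain swap each held on both cores, but they cover only these two side chains in this one assay, and they do not explain why the methyl weakens the compounds.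

The compounds shown leave open whether a different group on that same aromatic carbon, such as an ethyl chain or a chlorine atom, would cost as much as the methyl or more. On these data alone, it also remains open whether the methyl's cost would persist with a quite different side chain, such as an amine or a carboxylic acid in place of the (carbamoyloxy)methyl group.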